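Working notes: from compound 3 to compound 4

The compounds below may be only part of what the source reports. "The series", "measured", "known", "first", "only" and "open" are said of these compounds alone.

Three compounds sharing one core have numbers in an ADME assay on microsomes from liver (Mus musculus) for metabolic stability; on this read-out higher numbers stand for a longer-lived compound and lower numbers for a shorter-lived compound: compound 1 `CC(C)C(c1ccc(-c2ccc3cccc(F)c3c2)[nH]c1=O)N1CCCCS1(=O)=O` gives 0.0733 h, compound 2 `CC(C)C(Cc1noc(=O)[nH]1)c1ccc(-c2ccc3cccc(F)c3c2)[nH]c1=O` gives 2.78 h, and compound 3 `CC(C)C(c1ccc(-c2ccc3cccc(F)c3c2)[nH]c1=O)N1CCNC1=O` gives 0.682 h. This places compound 3 second highest of the three.

The unmeasured compound 4 `Cc1c[nH]c(C(c2ccc(-c3ccc4cccc(F)c4c3)[nH]c2=O)C(C)C)n1` carries 4-methyl-1H-imidazol-2-yl in place of 2-oxoimidazolidin-1-yl on a saturated chain carbon bound to an aromatic carbon and a saturated chain carbon.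

All three measured steps are changes at this same carbon, so all bear on the new one. The first is large, at a 38-fold higher number from compound 1 to compound 2 (1.58 log units; beyond the scatter), and the others modest, at a 9.3-fold higher number from compound 1 to compound 3 (0.97 log units; beyond the scatter) and a 4.1-fold lower number from compound 2 to compound 3 (0.61 log units; beyond the scatter). For the measured compounds named here, the last of these is the only comparison involving an aromatic five-membered ring at this carbon, and a single pair gives no firm direction. Going by the values given here, no measured compound carries the entering group.

The expected outcome is therefore a 1.1-fold lower number from compound 3 to compound 4 (0.06 log units; within the scatter), although a modest step either way remains possible. For compound 4 the estimate is 0.6 h, with an expected range of 0.15 h to 2 h.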

Compound 4, half-life: < 0.0667 h
Compound 4: only a limit was reported; the forecaster's own chance of this, stated with the estimate: 2%; middle value at least 8.9-fold (0.95 log units) from the limit.
By their numbers in this assay, from the lowest: compound 1; then compound 3; then compound 2. At a limit, below all of these: compound 4.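

In this assay the reading for compound 4 is a limit and not a number: the limit of < 0.0667 h in this assay, at which 1 of the 4 values shown sits. At this saturated chain carbon, five-membered aromatic rings now give widely separated outcomes, with an at least 41-fold lower number from compound 2 to compound 4 (1.61 log units; beyond the scatter), so an aromatic ring here does not by itself go with a longer-lived compound. Replacing 2-oxoimidazolidin-1-yl with 4-methyl-1H-imidazol-2-yl also gives an at least 10-fold lower number from compound 3 to compound 4 (1.00 log units; beyond the scatter), a change that takes the series to the short-lived end, while an at least 1.0-fold lower number from compound 1 to compound 4 (0.04 log units; that floor lies within the scatter) does not separate those two compounds.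

As far as these compounds go, it remains open how far compound 4 lies past its limit and how much of the step belongs to the methyl group rather than the ring. An unsubstituted imidazol-2-yl or a carboxylic acid at this carbon would bear on that question.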